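Swapping Diethylamino for a Carboxy Amide in Splenocyte Cytotoxicity

The source may hold more compounds than are shown below. What is called first, only, known or untested is meant among the compounds shown, and "the series" means these compounds.

Of the compounds shown here, three have been measured in an ADME assay on cells (Splenocyte, Mus musculus, strain BALB/c) for cytotoxicity, read by MTT assay, tested at 1 ug/mL; on this read-out higher numbers stand for a stronger effect at the one concentration tested and lower numbers for a weaker effect. Compound 2 `CCCCCCCCCCCCCCC(COCc1ccccc1)N(CC)CC` gives 14.1% and compound 1 `CCCCCCCCCCCCCCC(COCc1ccccc1)NC(=O)CCCC(=O)O` gives 0%; the single difference between them is ((3-carboxypropyl)carbonyl)amino in place of diethylamino on a saturated chain carbon bound to two saturated chain carbons and it made the step of a number 14.1 percentage points lower from compound 2 to compound 1 (beyond the scatter). Compound 3 `CCCCCCCCCCCCCCC(CN(CC)CC)NC(=O)OC(C)(C)C` gives 6.5% in this assay; how its core differs from that of compound 2 is not broken down here. Compound 4 `CCCCCCCCCCCCCCC(CNC(=O)CCCC(=O)O)NC(=O)OC(C)(C)C` is still to be measured in this assay. It differs from compound 3 by ((3-carboxypropyl)carbonyl)amino in place of diethylamino on a saturated chain carbon, two bonds along the chain from an amide-type nitrogen, the same kind of change as that from compound 2 to compound 1, though the place is not identical: a carbon bound to two saturated chain carbons in the one case, a carbon two bonds along the chain from an amide-type nitrogen in the other. Because of the step of a number 14.1 percentage points lower from compound 2 to compound 1 (beyond the scatter), compound 4 is expected to come out lower than compound 3. The expected step is a number 5.5 percentage points lower from compound 3 to compound 4 (within the scatter). Compound 4 is estimated at 1%, between 0% and 10%.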

Compound 4, a percentage reported as activity, at one concentration (the size of the read-out at that concentration, not a potency): 0%
Compound 4: middle estimate off by 1 percentage points, on the high side; low and high end bracket the measured number.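

In this assay, the same replacement of diethylamino by ((3-carboxypropyl)carbonyl)amino on the second core gives a number 6.5 percentage points lower from compound 3 to compound 4 (within the scatter), and the two steps can be set side by side: the same change on two cores in this assay, a number 14.1 percentage points lower (beyond the scatter) from compound 2 to compound 1 and a number 6.5 percentage points lower (within the scatter) from compound 3 to compound 4, 7.6 percentage points apart, within the scatter of two such steps. The change therefore carries from one core to the other with no difference in step size that can be told from the scatter. Among the compounds shown here, it does not show a real drop on the core of compound 3, as only the step on the core of compound 2 lies beyond the scatter, and two cores establish no rule for the series.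

The compounds shown leave open how a primary amine or a morpholine would read in place of these groups. They also leave open whether a shorter chain would alter the step.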